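A pyridin-4-yl swap at the assay limit

A few compounds are considered here, and "the series" means these few. Any claim that something is new, unique, unknown or untested is made for them only; others in the source may bear on it.

Measured in a functional assay on Bel-7402 cells (Homo sapiens) for inhibition, read by sulforhodamine B assay, with a stated time of 72 h; on this read-out lower numbers stand for stronger inhibition and higher numbers for weaker inhibition:
compound 1 `C[C@H](Nc1ncnc2[nH]cnc12)c1nn(-c2ccccn2)c2cc(F)ccc12`: > 40000 nM (a limit)
compound 2 `C[C@H](Nc1ncnc2[nH]cnc12)c1nn(-c2cccc(S(C)(=O)=O)c2)c2cc(F)ccc12`: 20000 nM
compound 3 `C[C@H](Nc1ncnc2[nH]cnc12)c1nn(-c2cc(F)cc(F)c2)c2cc(F)ccc12`: > 40000 nM (a limit)

In this assay compound 3 gives > 40000 nM, which is a limit and not a number. Compound 3 thus stands at the limit of > 40000 nM in this assay, at which 2 of the 3 values shown sit. The next compound, compound 4 `C[C@H](Nc1ncnc2[nH]cnc12)c1nn(-c2ccncc2)c2cc(F)ccc12`, differs from it in one place: pyridin-4-yl in place of 3,5-difluorophenyl on an aromatic nitrogen. Pyridin-4-yl stands in place of 3,5-difluorophenyl on an aromatic nitrogen.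

Going by the values given here, three measured steps bear on this change. Compound 1 carries pyridin-2-yl, the measured group most like the entering one, and the exchange for 3,5-difluorophenyl gave a step that the two limits leave unreadable from compound 1 to compound 3. The 3-(methylsulfonyl)phenyl group of compound 2 gave an at least 2.0-fold lower number from compound 1 to compound 2 (0.30 log units; that floor lies within the scatter), and its exchange for 3,5-difluorophenyl gave an at least 2.0-fold higher number from compound 2 to compound 3 (0.30 log units; that floor lies within the scatter). Among the compounds with values here, both of these floors lie within the scatter, so no measured step shows a size beyond it. No step beyond the scatter is therefore expected in this assay, and a report of only a limit is likely. The expected step is a number no higher from compound 3 to compound 4 (the limit leaves the size open). For compound 4 the estimated value is 40000 nM, with an expected range from 18000 nM to 90000 nM.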

Compound 4, half-maximal inhibitory concentration: > 40000 nM
Compound 4: only a limit was reported; the forecaster's own chance of this, stated with the estimate: 70%; the middle value lies on the limit itself.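

In this assay compound 4 gives > 40000 nM, which is a limit of the assay and not a number. Set against compound 2, the only compound shown with a number, the change gives an at least 2.0-fold higher number from compound 2 to compound 4 (0.30 log units; that floor lies within the scatter), while the steps to compound 4 from compound 1 and from compound 3 cannot be read, as each joins two limits. What is new is that a ring with a hetero atom on this aromatic nitrogen has now given no number as pyridin-4-yl as well as pyridin-2-yl, so the 3-(methylsulfonyl)phenyl group of compound 2 remains alone in giving a readable value, and the set now gathers at one end of the scale: the limit of > 40000 nM in this assay, at which 3 of the 4 values shown sit.

As far as these compounds go, how far compound 1, compound 3 and compound 4 lie past that limit stays open, and so does whether the place of the ring nitrogen matters at all in this assay. Also open, from the compounds shown here alone, is whether pyridin-3-yl, a phenyl ring bearing an amine or a carboxylic acid, or a plain methyl or longer chain in place of the ring would give a number at this position.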